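Diaryl urea pyridyl ethers: triazole substituent change

The source may hold more compounds than are shown below. What is called first, only, known or untested is meant among the compounds shown, and "the series" means these compounds.

Working notes on the series. In a functional assay on MDA-MB-231 cells (Homo sapiens) for antiproliferative activity, read by MTT assay, with a stated time of 72 h (a lower number here means a stronger inhibitor, a higher number a weaker inhibitor), compound 1 `Cn1ncnc1-c1cc(Oc2ccc(NC(=O)Nc3cccc(C(F)(F)F)c3)cc2F)ccn1` gives 9680 nM. Among the compounds with values here, the only other measured member, compound 2 `CN(C)CCn1cnnc1-c1cc(Oc2ccc(NC(=O)Nc3ccc(Cl)cc3Cl)cc2F)ccn1`, gives 7960 nM in this assay; the two numbers sit within the scatter of each other, so compound 1 stands level with compound 2. Compound 3 `CCN(CC)CCn1cnnc1-c1cc(Oc2ccc(NC(=O)Nc3cccc(C(F)(F)F)c3)cc2F)ccn1` is not yet measured and differs from compound 1 by 4-(2-(diethylamino)ethyl)-4H-1,2,4-triazol-3-yl in place of 1-methyl-1H-1,2,4-triazol-5-yl on an aromatic carbon. Within the data shown here, no measured pair isolates this change. With compound 2 giving 7960 nM, no step beyond the scatter is expected here; the expected step of a 1.4-fold lower number from compound 1 to compound 3 (0.14 log units; within the scatter) is small. Compound 3 is estimated at 7000 nM, range 2500 nM to 20000 nM.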

Compound 3, half-maximal inhibitory concentration: 720 nM
Beside the measured number, compound 3's estimate is 9.7-fold (0.99 log units) above it; the whole stated range lies above it.
By their numbers in this assay, from the lowest: compound 3; then compounds 2 and 1 (each within the scatter of the next).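

In this assay, within the data shown here, the group on this aromatic carbon clearly matters: 4-(2-(diethylamino)ethyl)-4H-1,2,4-triazol-3-yl in place of 1-methyl-1H-1,2,4-triazol-5-yl gives a 13-fold lower number from compound 1 to compound 3 (1.13 log units; beyond the scatter) and is the only step beyond the scatter. The change alters the triazole substitution pattern and the side chain together, so this single step cannot separate the two. No available evidence accounts for the step.

Open, on these data alone, is whether 4-methyl-4H-1,2,4-triazol-3-yl alone would match compound 3. Also open, as far as these compounds go, is whether a morpholine or pyrrolidine in place of the diethylamino group, or a longer chain, would hold the lower number.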